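Turning One Stereocentre: From Compound 3 to Compound 4

The compounds below may be only part of what the source reports. "The series", "measured", "known", "first", "only" and "open" are said of these compounds alone.

Measured in an ADME assay on the whole organism for inhibition, with Echinochloa crus-galli var. formosensis as the target, with a stated time of 4 days; a lower number here means a stronger inhibitor, a higher number a weaker inhibitor:
Compound 1, `CNc1nc(Cl)nc(N[C@@H](C)c2ccccc2)n1`, gives 26900 nM
Compound 2, `CC[C@@H](C)Nc1nc(Cl)nc(N[C@@H](C)c2ccccc2)n1`, gives 7410 nM
Compound 3, `CC(C)Nc1nc(Cl)nc(N[C@@H](C)c2ccccc2)n1`, gives 11000 nM

Compound 3 stands second highest of the three numbers. Its nearest neighbour is compound 2, and the step of a 1.5-fold higher number from compound 2 to compound 3 (0.17 log units; within the scatter) lies within the scatter, so the two cannot be told apart. The step of a 2.4-fold lower number from compound 1 to compound 3 (0.39 log units; beyond the scatter) is beyond the scatter, as is a 3.6-fold lower number from compound 1 to compound 2 (0.56 log units; beyond the scatter); both steps swap a larger group for the methyl on the ring nitrogen.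

Compound 4, `CC(C)Nc1nc(Cl)nc(N[C@H](C)c2ccccc2)n1`, differs from compound 3 only in configuration: the two compounds have the same atoms and bonds and differ only in configuration as drawn: 1 of 1 stereo elements differ; a stereocentre at a saturated chain carbon is drawn S in compound 3 and R in compound 4.

Within the data shown here, none of the measured steps touches a stereocentre; all three measured compounds carry the same configuration at that chain carbon. The measured data therefore give no direct guide to the size or direction of the step in this assay. A change of configuration can leave the number unchanged or move it strongly either way, so a broad range is warranted. The estimate for compound 4 in this assay is 25000 nM, in the range 7000 nM to 100000 nM, which means an expected step of a 2.3-fold higher number from compound 3 to compound 4 (0.36 log units; beyond the scatter).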

Compound 4, half-maximal inhibitory concentration: 2000 nM
Compound 4: middle estimate off by 13-fold (1.10 log units), on the high side, and the stated range ends above it.
By their numbers in this assay, from the lowest: compound 4; then compounds 2 and 3 (each within the scatter of the next); then compound 1.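

In this assay, turning this one stereocentre from S to R gives a 5.5-fold lower number from compound 3 to compound 4 (0.74 log units; beyond the scatter), so the arrangement in space at this chain carbon counts in its own right, with no atom added or taken away. The earlier compounds shown here all share one configuration at this carbon, so they could speak only to the group on the nitrogen on the aromatic ring; this pair shows that the chain carbon is a second place where the number can move, and that the R form gives the lower number here. The shift can be assigned to this stereocentre alone, because the pair offers no other difference: the fact that compounds 3 and 4 differ only in the configuration as drawn.

Going by these compounds, only the isopropyl compounds are compared in both configurations, so it remains open whether the R form also gives the lower number with methyl or sec-butyl on that nitrogen. Also open, on these data alone, is what a longer chain or a cyclopropyl group on that nitrogen would do when paired with the R configuration, and whether the preference survives if a methoxy group takes the place of the chlorine on the shared core.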